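The source may report more compounds than this note shows. Statements on the series, on what has been measured and on what is new or still open speak of the compounds shown alone.

Measured so far, in an ADME assay on HUVEC cells (Homo sapiens) for antiproliferative activity, read by MTT assay, with a stated time of 48 h; a higher number here means a weaker inhibitor, a lower number a stronger inhibitor:
Compound 1 `Cc1ccc(C)c(-n2nncc2CN2C(=O)C3(C(C#N)=C(N)Oc4c(N)cc5nc6ccccc6nc5c43)c3ccccc32)c1` gives > 50000 nM, which is a limit of the assay and not a number.
Compound 2 `CCc1cccc(CC)c1-n1nncc1CN1C(=O)C2(C(C#N)=C(N)Oc3c(N)cc4nc5ccccc5nc4c32)c2ccccc21` gives > 50000 nM, again a limit of the assay.
Compound 3 `N#CC1=C(N)Oc2c(N)cc3nc4ccccc4nc3c2C12C(=O)N(Cc1cnnn1-c1ccc(F)c(Cl)c1)c1ccccc12` gives > 50000 nM, likewise a limit of the assay.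

All three compounds share one core and differ only in the aryl group carried on an aromatic nitrogen of the triazole. None of them shows a readable number in this assay; every value sits at the limit of > 50000 nM in this assay, at which 3 of the 3 values shown sit. So compound 3 stands, in the shown data, exactly where compound 1 and compound 2 stand: at the edge of what the assay can report, with no antiproliferative activity measurable on these cells.

The step to the new compound 4 `N#CC1=C(N)Oc2c(N)cc3nc4ccccc4nc3c2C12C(=O)N(Cc1cnnn1-c1c(Cl)cc(Cl)cc1Cl)c1ccccc12` is again a swap of that aryl group: 2,4,6-trichlorophenyl in place of 3-chloro-4-fluorophenyl on an aromatic nitrogen. The measured steps that bear on it are the three earlier aryl swaps, a step that the two limits leave unreadable from compound 1 to compound 2, a step that the two limits leave unreadable from compound 1 to compound 3 and a step that the two limits leave unreadable from compound 2 to compound 3, each of them unreadable in size. Three different aryl groups have left the value at the limit, so the expectation for compound 4 in this assay is no step beyond the scatter, a step that the limit leaves unreadable from compound 3 to compound 4, and most likely a fourth limit. The estimate for compound 4 is 60000 nM, within 20000 nM to 200000 nM.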

Compound 4, half-maximal inhibitory concentration: 18300 nM
The estimate for compound 4 lay 3.3-fold (0.52 log units) above the measured number; measured number below the stated range.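

In this assay, for the compounds shown here, the aryl group on the aromatic nitrogen now proves able to shift the read-out, since 2,4,6-trichlorophenyl gives the first readable number, with an at least 2.7-fold lower number from compound 3 to compound 4 (0.43 log units; beyond the scatter), along with an at least 2.7-fold lower number from compound 2 to compound 4 (0.43 log units; beyond the scatter) and an at least 2.7-fold lower number from compound 1 to compound 4 (0.43 log units; beyond the scatter). Carrying a chlorine is not enough on its own: compound 3, whose 3-chloro-4-fluorophenyl group has one, gives > 50000 nM, which is a limit of the assay and not a number. The steps among compound 1, compound 2 and compound 3 cannot be read, so compound 4 is the only one that gives any measure of how much this group matters, and the true size of its steps stays hidden: the limit of > 50000 nM in this assay, at which 3 of the 4 values shown sit.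

The compounds shown do not tell whether all three chlorines of compound 4 are needed, or whether a 2,6-dichlorophenyl or 4-chlorophenyl group would give a similar number. They also leave open how this position would respond to a group of a different kind, such as a phenyl ring bearing an amine or a carboxylic acid, or a longer alkyl chain in place of the aryl ring.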